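Aryl substituent steps on the shared core

This account rests on a few compounds, and the source may have more. Where it says the series, first, only, none or still open, it means among the compounds named here.

Measured so far:
compound 1 `O=S(=O)(NCCCNCc1ccc(Cl)cc1)c1cc(C(F)(F)F)cc(C(F)(F)F)c1` gives 2800 nM
compound 2 `O=S(=O)(NCCCNCc1ccc(-c2ccccc2)cc1)c1cc(C(F)(F)F)cc(C(F)(F)F)c1` gives 2700 nM
compound 3 `COc1ccccc1CNCCCNS(=O)(=O)c1cc(C(F)(F)F)cc(C(F)(F)F)c1` gives 2400 nM

In a functional assay on HPAC cells (Homo sapiens) for inhibition, read by MTT assay, with a stated time of 72 h (a higher number here means a weaker inhibitor of growth, a lower number a stronger inhibitor of growth), compound 1 holds the highest of the three numbers, yet the step of a 1.0-fold lower number from compound 1 to compound 2 (0.02 log units; within the scatter) and the step of a 1.2-fold lower number from compound 1 to compound 3 (0.07 log units; within the scatter) both lie within the scatter, so the three compounds cannot be ordered. Compound 4 `COc1ccc(CNCCCNS(=O)(=O)c2cc(C(F)(F)F)cc(C(F)(F)F)c2)cc1` differs from compound 1 by methoxy in place of chloro on an aromatic carbon. The two measured steps bear on this: each alters the same aryl group on the saturated chain carbon bound to the amine nitrogen, and neither moved the number beyond the scatter. The step of a 1.1-fold lower number from compound 1 to compound 4 (0.03 log units; within the scatter) is therefore expected to stay within the scatter as well. Compound 4 is estimated at 2600 nM, with a range of 1300 nM to 5200 nM.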

Compound 4, concentration for 50% growth inhibition: 3000 nM
Compound 4: the middle estimate sits 1.2-fold (0.06 log units) below what was measured, within the range that was stated.
By their numbers in this assay, from the lowest: compounds 3, 2, 1 and 4 (each within the scatter of the next).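

In this assay, the methoxy of compound 4 brings an oxygen and one hydrogen-bond acceptor, yet a 1.1-fold higher number from compound 1 to compound 4 (0.03 log units; within the scatter) is a step that stays within the scatter. The placement of methoxy on the aryl group and the choice of methoxy over phenyl are equally unresolved, as a 1.3-fold higher number from compound 3 to compound 4 (0.10 log units; within the scatter) and a 1.1-fold higher number from compound 2 to compound 4 (0.05 log units; within the scatter) both remain within the scatter. No supporting evidence accounts for this flat response.

As far as these compounds go, whether an amine or a carboxylic acid at this aromatic carbon would give a step beyond the scatter remains open. Also open, from the compounds shown here alone, is how a longer chain in place of the present one would read in this assay on the shared core.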